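Swapping the acyl aryl group in a thiazole-hydrazone series

The compounds below may be only part of what the source reports. "The series", "measured", "known", "first", "only" and "open" are said of these compounds alone.

Measured so far:
compound 1 `CN(C(=O)NC(=O)c1ccc([N+](=O)[O-])cc1)c1nc(C(F)(F)F)c(C(=O)N/N=C/c2cccc(C(F)(F)F)c2)s1` gives 4.39 ug/mL
compound 2 `CN(C(=O)NC(=O)c1ccc([N+](=O)[O-])cc1)c1nc(C(F)(F)F)c(C(=O)N/N=C/c2ccc([N+](=O)[O-])cc2)s1` gives 9.24 ug/mL
compound 3 `CN(C(=O)NC(=O)c1ccc(Cl)c(Cl)c1)c1nc(C(F)(F)F)c(C(=O)N/N=C/c2cccc([N+](=O)[O-])c2)s1` gives 7.51 ug/mL

In a functional assay on MCF7 cells (Homo sapiens) for inhibition, read by MTT assay, with a stated time of 72 h (on this read-out higher numbers stand for weaker inhibition and lower numbers for stronger inhibition), compound 1 stands lowest of the three numbers. Within the data shown here, compound 3 is its nearest neighbour, a gap within the usual scatter, while compound 2 lies furthest from it, the one measured step that is beyond the scatter: a 2.1-fold higher number from compound 1 to compound 2 (0.32 log units; beyond the scatter). Compound 4 `CN(C(=O)NC(=O)c1ccc(Cl)cc1Cl)c1nc(C(F)(F)F)c(C(=O)N/N=C/c2cccc(C(F)(F)F)c2)s1` has not yet been tested in this assay. It departs from compound 1 by 2,4-dichlorophenyl in place of 4-nitrophenyl on a carbonyl carbon, a change on the carbonyl carbon next to the amide-type nitrogen. Among the measured compounds shown here, no measured step touches that position: the step from compound 1 to compound 2 changes the aryl group on the carbon doubly bonded to nitrogen instead. Compound 3, which carries a chlorinated aryl on the carbonyl carbon but also a different hydrazone aryl, gives 7.51 ug/mL against 4.39 ug/mL for compound 1, a difference within the scatter. With nothing pointing either way, compound 4 is expected to stay close to compound 1, the step of a 1.0-fold higher number from compound 1 to compound 4 (0.01 log units; within the scatter) not clearly beyond the scatter. The estimate for compound 4 is therefore 4.5 ug/mL, expected to fall between 2.3 ug/mL and 9 ug/mL.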

Compound 4, half-maximal inhibitory concentration: 10.7 ug/mL
Compound 4: the middle estimate sits 2.4-fold (0.38 log units) below what was measured; measured number above the stated range.
By their numbers in this assay, from the lowest: compounds 1, 3, 2 and 4 (each within the scatter of the next, the first and the last beyond it).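

In this assay, among these compounds, the first measured step at this position shows that the aryl group on the carbonyl carbon affects the read-out: a 2.4-fold higher number from compound 1 to compound 4 (0.39 log units; beyond the scatter), with 2,4-dichlorophenyl in place of 4-nitrophenyl and the 3-(trifluoromethyl)phenyl on the carbon with a double bond to nitrogen unchanged. Among the compounds shown here, until now, the only step beyond the scatter lay at that other place, a 2.1-fold higher number from compound 1 to compound 2 (0.32 log units; beyond the scatter), so both places have now given a modest step, and at this position 4-nitrophenyl gives the lower number of the pair. Nothing measured here accounts for the step.

From the compounds shown here alone, this single swap removes the nitro group and brings in two chlorines at once, so it remains open which part of the exchange goes with the higher number; a plain phenyl, or a phenyl carrying a single chlorine, on the same carbonyl carbon would separate the two. Also open, going by these compounds, is whether the step would keep its direction and size with another aryl group on the carbon with a double bond to nitrogen, or with a cyclohexyl group in place of the aryl on the carbonyl carbon.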